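Swapping chloro for trifluoromethoxy on a thiourea amide

The source may report more compounds than this note shows. Statements on the series, on what has been measured and on what is new or still open speak of the compounds shown alone.

Compound 1 `CC(C)NC(=O)c1cc(Oc2cccc(NC(=S)Nc3ccc(Cl)cc3)c2)ccn1` is the starting point. In a functional assay on HCT-116 cells (Homo sapiens) for cytotoxicity, read by MTT assay, with a stated time of 48 h (on this read-out higher numbers stand for weaker inhibition and lower numbers for stronger inhibition), compound 1 gives 22100 nM; of the three numbers in hand its is the largest, yet none of the three stands beyond the scatter from another. Compound 2 `O=C(NCc1ccccc1)c1cc(Oc2cccc(NC(=S)Nc3ccc(Cl)cc3)c2)ccn1` gives 16500 nM in this assay, and compound 3 `O=C(c1cc(Oc2cccc(NC(=S)Nc3cccc(C(F)(F)F)c3)c2)ccn1)N1CCCC1` gives 19200 nM. Within the data shown here, the single known step, a 1.3-fold lower number from compound 1 to compound 2 (0.13 log units; within the scatter), concerns the amide-type nitrogen, not the thiourea end. Compound 4 `CC(C)NC(=O)c1cc(Oc2cccc(NC(=S)Nc3ccc(OC(F)(F)F)cc3)c2)ccn1` carries trifluoromethoxy in place of chloro on an aromatic carbon, para to a large group, so that the change reads 4-chlorophenyl to 4-(trifluoromethoxy)phenyl. Among the measured compounds shown here, no measured step touches this position, and the amide step gives no sign of movement. On that basis the expected step is a 1.1-fold lower number from compound 1 to compound 4 (0.04 log units; within the scatter). For compound 4 the estimated value is 20000 nM, with a range from 8000 nM to 50000 nM.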

Compound 4, half-maximal inhibitory concentration: 18100 nM
Compound 4: the middle estimate sits 1.1-fold (0.04 log units) above what was measured, within the range that was stated.
By their numbers in this assay, from the lowest: compounds 2, 4, 3 and 1 (each within the scatter of the next).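

Among these compounds, the step at the 4-chlorophenyl end, absent from the earlier compounds, is a 1.2-fold lower number from compound 1 to compound 4 (0.09 log units; within the scatter) in this assay. On this aromatic carbon, chloro and the larger trifluoromethoxy, which adds a hydrogen-bond acceptor, therefore give values within the scatter of each other. Nothing measured here accounts for this result. On these data alone, it remains open how an amine or a carboxylic acid on this aromatic carbon would read in the same assay. Also open, as far as these compounds go, is whether trifluoromethoxy in place of chloro would give a similar step in the benzyl amide, compound 2.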